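Adding a methyl group to compound 1

The source may report more compounds than this note shows. Statements on the series, on what has been measured and on what is new or still open speak of the compounds shown alone.

Compound 1 `O=C1C(Nc2ccccc2)=CC(=O)c2c1nc1n2[C@H]2OC[C@@H](O)[C@H]2OC1`: 1830 nM
Compound 2 `O=C1C=C(Nc2ccccc2F)C(=O)c2c1nc1n2[C@H]2OC[C@@H](O)[C@H]2OC1`: 2080 nM

In a functional assay on MGC-803 cells (Homo sapiens) for inhibition, read by sulforhodamine B assay (on this read-out lower numbers stand for stronger inhibition and higher numbers for weaker inhibition), compound 1 gives 1830 nM and compound 2 gives 2080 nM. For the measured compounds named here, these two values lie within the usual scatter of each other, so compound 1 stands level with the only other measured compound. Compound 3 `Cc1ccc(NC2=CC(=O)c3c(nc4n3[C@H]3OC[C@@H](O)[C@H]3OC4)C2=O)cc1` is not yet measured and differs from compound 1 by methyl in place of hydrogen on an aromatic carbon. Going by the values given here, no measured step covers this change. In this assay no step beyond the scatter is expected, and no direction is favoured. The estimated change is a 1.1-fold lower number from compound 1 to compound 3 (0.03 log units; within the scatter). Compound 3 is expected at 1700 nM, with an estimated range of 800 nM to 3500 nM.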

Compound 3, half-maximal inhibitory concentration: 1550 nM
Compound 3: middle estimate off by 1.1-fold (0.04 log units), on the high side; the range from low to high includes it.
By their numbers in this assay, from the lowest: compounds 3, 1 and 2 (each within the scatter of the next).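

In this assay the change from phenyl to 4-methylphenyl gives a 1.2-fold lower number from compound 1 to compound 3 (0.07 log units; within the scatter) and so shows that a single methyl group on this aromatic carbon, para to a large group, brings no step beyond the scatter. For the compounds shown here, this is the first step read at this position. Nothing at hand bears on the reason for this result.

As far as these compounds go, whether a longer chain such as ethyl, or a methoxy group, an amine or a carboxylic acid at this same carbon would shift the number remains open. Also open, from the compounds shown here alone, is whether methyl on the other carbons of this ring would behave the same way.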